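Same Exchange on a Shorter Chain: Expecting Compound 4

The source may report more compounds than this note shows. Statements on the series, on what has been measured and on what is new or still open speak of the compounds shown alone.

Measured so far:
- Compound 1 `C#CCNC1CCc2c(SCCc3ccc(Br)cc3)cccc21`: 85300 nM
- Compound 2 `C#CCNC1CCc2c(SCCc3cccc(C)c3)cccc21`: 0.35 nM
- Compound 3 `C#CCNC1CCc2c(SCc3cccc(C)c3)cccc21`: > 100000 nM

In an assay on isolated protein for inhibition of Amine oxidase [flavin-containing] B (Homo sapiens) (on this read-out higher numbers stand for weaker inhibition and lower numbers for stronger inhibition), compound 2 gives 0.35 nM. In this assay compound 1 gives 85300 nM. The two share a core and differ in one place: 4-bromophenyl in place of 3-methylphenyl on a saturated chain carbon, two bonds along the chain from a sulfur. That single exchange gives a 240000-fold higher number from compound 2 to compound 1 (5.39 log units; beyond the scatter).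

Compound 3 stands at a limit of this assay, not at a number: the value > 100000 nM is a limit, and compound 3 is among those that sit at the limit of > 100000 nM in this assay, at which 1 of the 3 values shown sits. How the core of compound 3 differs from the core of compound 2 is not broken down here.

Compound 4 `C#CCNC1CCc2c(SCc3ccc(Br)cc3)cccc21` has not yet been measured in this assay. It relates to compound 3 through the same kind of change that turned compound 2 into compound 1: 4-bromophenyl in place of 3-methylphenyl on a saturated chain carbon bound to a sulfur. The place is not the same word for word: in compound 4 the group enters on a saturated chain carbon bound to a sulfur, whereas in compound 1 it enters on a saturated chain carbon two bonds along the chain from a sulfur.

Because compound 3 already sits at the limit of > 100000 nM in this assay, at which 1 of the 3 values shown sits, and the earlier exchange gave a 240000-fold higher number from compound 2 to compound 1 (5.39 log units; beyond the scatter), compound 4 is expected to remain at or beyond that limit. The expected step is a step that the limit leaves unreadable from compound 3 to compound 4, and compound 4 is estimated at 300000 nM, with a range from 100000 nM to 3000000 nM.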

Compound 4, half-maximal inhibitory concentration: 1310 nM
The estimate for compound 4 lay 230-fold (2.36 log units) above the measured number, outside the stated range (below it).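

In this assay, placing 4-bromophenyl in place of 3-methylphenyl on a saturated chain carbon bound to a sulfur gives an at least 76-fold lower number from compound 3 to compound 4 (1.88 log units; beyond the scatter), so the exchange that sharply weakened inhibition on the core of compound 2 strengthens it on the core of compound 3. Set side by side, the two results run in opposite directions, and the gap between them is far larger than measurement scatter could produce: the same change on two cores in this assay, a 240000-fold higher number (5.39 log units; beyond the scatter) from compound 2 to compound 1 and an at least 76-fold lower number (1.88 log units; beyond the scatter) from compound 3 to compound 4, at least 18000000-fold (7.26 log units) apart, beyond the scatter of two such steps Compound 3 has a limit rather than a number, > 100000 nM, so the full size of its step stays unknown, and although this pair shows that neither the size nor the direction of the exchange carried over from one core to the other, two pairs of compounds cannot explain the reversal or set a rule for other cores.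

The compounds shown leave open whether the reversal depends on the bromine, on the methyl group or on where each sits on the ring, a question that a plain phenyl or a chlorine in place of the bromine could help to answer on both cores. They also leave open how the same exchange would behave on a longer chain.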